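The compounds below may be only part of what the source reports. "The series", "measured", "known", "first", "only" and "open" are said of these compounds alone.

Among the compounds with values here, compound 2 `COC(=O)c1cccc(NC(=O)c2cccc(-c3cc(C(=O)Nc4ccncc4F)ccc3CN)c2)c1F` is one of two compounds measured in an ADME assay on a cell-free system (plasma, Homo sapiens) for metabolic stability, read by LC-MS; on this read-out higher numbers stand for a longer-lived compound and lower numbers for a shorter-lived compound. In this assay compound 2 gives < 0.0834 h, which is a limit of the measurement rather than a number, namely (the limit of < 0.0834 h in this assay, at which 1 of the 2 values shown sits). Compound 1 `NCc1ccc(C(=O)Nc2ccncc2F)cc1-c1cccc(C(=O)Nc2cccc(CC(=O)O)c2)c1` differs from it in one place. In this assay compound 1 gives > 2 h, again a limit and not a number, namely (the limit of > 2 h in this assay, at which 1 of the 2 values shown sits). Between the two lies a single measured step, an at least 23-fold lower number from compound 1 to compound 2 (1.37 log units; beyond the scatter), which exchanges 3-(carboxymethyl)phenyl for 2-fluoro-3-(methoxycarbonyl)phenyl on an amide-type nitrogen.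

Compound 3 `NCc1ccc(C(=O)Nc2ccncc2F)cc1-c1cccc(C(=O)Nc2cccc(C(=O)O)c2F)c1` has not yet been measured. It differs from compound 2 by hydrogen in place of methyl on an oxygen next to a carbonyl group, so that methoxycarbonyl becomes carboxy and 2-fluoro-3-(methoxycarbonyl)phenyl becomes 3-carboxy-2-fluorophenyl. This change undoes part of the measured step: compound 3, like compound 1, carries a free acid where compound 2 carries a methyl ester. On that basis a large rise is expected, an at least 35-fold higher number from compound 2 to compound 3 (1.55 log units; beyond the scatter). Compound 3 is therefore estimated at 3 h in this assay, with a range from 0.5 h to 12 h.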

Compound 3, half-life: > 2 h
Compound 3 gave a limit, no number (the forecaster's own chance of this, stated with the estimate: 65%); the middle value does not contradict the limit.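

Compound 1 and compound 2 differ in a whole group on an amide-type nitrogen, so their gap could not be pinned on any one part of that group. Here only methyl gives way to hydrogen on an oxygen next to a carbonyl group, with the fluorine kept, and that single change brings an at least 23-fold higher number from compound 2 to compound 3 (1.37 log units; beyond the scatter) in this assay. Within this pair the methoxycarbonyl group, and not the fluorine, goes with the short-lived end of the read-out, and compound 3 ends at a limit rather than a number: the limit of > 2 h in this assay, at which 2 of the 3 values shown sit.

The step from compound 1 to compound 3 cannot be read, as both values are limits, so the carboxy and carboxymethyl groups stay unranked against each other. Also open, from the compounds shown here alone, is where an ethyl ester or a carboxamide in place of the methoxycarbonyl group would fall in this assay, and whether a methoxycarbonyl group on a phenyl ring without the fluorine would behave as it does in compound 2.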